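A Piperazine for Piperidine in a Potent Sulfonamide

This account rests on a few compounds, and the source may have more. Where it says the series, first, only, none or still open, it means among the compounds named here.

Compound 1 `Cc1cc(C)c(S(=O)(=O)N2CCC(N3CCC(C)CC3)CC2)c(C)c1`: 0.03 nM
Compound 2 `COc1ccccc1-c1ccc(S(=O)(=O)N2CCC(N3CCC(C)CC3)CC2)cc1`: 26 nM

Within the data shown here, in a functional assay on DLD-1 cells (Homo sapiens) for antiproliferative activity, read by CellTiter-Glo, with a stated time of 72 h (a lower number here means a stronger inhibitor, a higher number a weaker inhibitor), compound 1 gives 0.03 nM, the lower of the two numbers measured so far. Compound 2 gives 26 nM, and the gap between them lies well beyond the usual scatter, so compound 1 is the stronger inhibitor of the pair.

Compound 3 `Cc1cc(C)c(S(=O)(=O)N2CCC(N3CCN(C)CC3)CC2)c(C)c1` has not yet been measured. It keeps the core of compound 1 and carries 4-methylpiperazin-1-yl in place of 4-methylpiperidin-1-yl on a saturated ring carbon. Among the measured compounds shown here, no measured pair yet isolates a change in one place, so the data offer no direct guide to the size of this step. For the measured compounds named here, the two values show only that numbers in this set can lie far apart. Going by the values given here, compound 1 stands at 0.03 nM, the lowest number so far, and a move toward a weaker inhibitor seems the likelier outcome. The expected step of a 17-fold higher number from compound 1 to compound 3 (1.22 log units; beyond the scatter) goes toward a higher number, beyond the scatter. For compound 3 the estimated value in this assay is 0.5 nM, with an expected range of 0.03 nM to 10 nM.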

Compound 3, half-maximal inhibitory concentration: 1100 nM
Compound 3: the middle estimate sits 2200-fold (3.34 log units) below what was measured, outside the stated range (above it).
By their numbers in this assay, from the lowest: compound 1; then compound 2; then compound 3.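

In this assay, among these compounds, a 37000-fold higher number from compound 1 to compound 3 (4.56 log units; beyond the scatter) gives the first reading of a change in one place, and the step is large and lies far beyond the scatter. The exchange is small on paper: the group keeps its 7 heavy atoms, its six-membered non-aromatic ring and its lack of net charge, while one ring carbon gives way to a nitrogen and the count of hydrogen-bond acceptors goes from 1 to 2. So this position, on a saturated ring carbon three ring bonds from the ring nitrogen, does not accept every group of the same size and shape, and almost all of the activity of compound 1 depends on what stands there; nothing available here accounts for the size of this loss.

As far as these compounds go, whether the loss follows from a second hetero atom in that ring as such remains open, and a morpholin-4-yl group, or a 4-hydroxypiperidin-1-yl group, would help separate the possibilities. Also open, from the compounds shown here alone, is whether the same exchange would cost as much on the sulfonyl side chain of compound 2.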